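This account rests on a few compounds, and the source may have more. Where it says the series, first, only, none or still open, it means among the compounds named here.

Measured so far in a functional assay for inhibition, with a stated time of 2 h, tested at 0.0156 g/L; a lower number here means less inhibition, a higher number more inhibition at the concentration tested (going by the name of the read-out):
compound 1 `COc1ccc(Nc2cccc3c(C)c(C)sc23)cc1` — 92.3%
compound 2 `Cc1sc2c(Nc3ccc(C#N)cc3)cccc2c1C` — 49.6%

Going by the values given here, compound 1 stands highest of the two numbers in this assay; the step of a number 42.7 percentage points lower from compound 1 to compound 2 (beyond the scatter) is cyano in place of methoxy on an aromatic carbon and is the only step measured. Compound 3 `COc1ccc(Nc2cccc3c(C)c(C)sc23)cc1OC` differs from compound 1 by methoxy in place of hydrogen on an aromatic carbon. Among the compounds with values here, no measured step concerns adding a second methoxy, so the one measured step bears on it only weakly. A step no larger than the scatter is expected, a number 4.3 percentage points lower from compound 1 to compound 3 (within the scatter). Compound 3 is therefore estimated at 88%, within 68% to 98%.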

Compound 3, a percentage reported as inhibition, at one concentration (the size of the read-out at that concentration, not a potency): 89.3%
Beside the measured number, compound 3's estimate is 1.3 percentage points below it; low and high end bracket the measured number.
By their numbers in this assay, from the lowest: compound 2; then compounds 3 and 1 (each within the scatter of the next).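

In this assay, the step for methoxy in place of hydrogen on this aromatic carbon, ortho to a methoxy group and meta to a large group, is a number 3 percentage points lower from compound 1 to compound 3 (within the scatter). The earlier step concerned replacing the existing methoxy with cyano, whereas this one shows that this second place can carry a methoxy with no change beyond the scatter. No evidence on the cause of this result is at hand.

The compounds shown leave open whether an amine or a carboxylic acid on this same carbon would also stay within the scatter of compound 1.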